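The compounds below may be only part of what the source reports. "The series", "measured", "known", "first", "only" and "open" are said of these compounds alone.

Working notes on a series built on one shared core, all read in a functional assay on BGC-823 cells (Homo sapiens) for cytotoxicity, read by CCK-8 assay, with a stated time of 72 h; on this read-out lower numbers stand for stronger inhibition and higher numbers for weaker inhibition. Compound 1, `C=CCn1c(=O)/c(=C\c2cccc(F)c2)[nH]c(=O)/c1=C\c1ccccc1OC`, gives 5600 nM in this assay; this is the only number shown for the series. Compound 2, `C=CCn1c(=O)/c(=C\c2cccc(Br)c2)[nH]c(=O)/c1=C\c1cccc(Br)c1`, is reported in this assay as "not active" (no number reported), with no number attached, so it cannot be set against compound 1 on a scale. Compound 1 therefore stands alone as the single measured point, neither strongest nor weakest by any shown comparison.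

Compound 3, `C=CCn1c(=O)/c(=C\c2ccccc2F)[nH]c(=O)/c1=C\c1ccccc1OC`, is not yet measured. It differs from compound 1 in one place: 2-fluorophenyl in place of 3-fluorophenyl on a double-bonded chain carbon bound to an aromatic carbon. The two have the same atoms, joined differently.

Within the data shown here, no step between two measured compounds is available to show how such a change plays out, so the expected size of the step rests on the change itself and on the single measured value. The expectation is that the step of a 1.1-fold higher number from compound 1 to compound 3 (0.03 log units; within the scatter) stays within the usual scatter of the assay, with no clear direction. Compound 3 is expected to give 6000 nM in this assay, in the range 2500 nM to 15000 nM.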

Compound 3, half-maximal inhibitory concentration: 18900 nM
Estimate against measurement, compound 3: 3.2-fold (0.50 log units) below; measured number outside the range, above it.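

In this assay, among these compounds, 2-fluorophenyl in place of 3-fluorophenyl on a double-bonded chain carbon bound to an aromatic carbon gives a 3.4-fold higher number from compound 1 to compound 3 (0.53 log units; beyond the scatter), the first step that can be read on a scale. Because compound 1 and compound 3 have the same atoms, joined differently, this modest step shows that the read-out can separate two arrangements of one atom set at this place, which compound 1 alone and the unquantified compound 2 could not show. The data shown include nothing that bears on the origin of this step, and one pair gives no wider trend for the series.

Among the compounds shown here, compound 2 has no number, so no step involving it can be read, and the single step leaves open whether the same change would give a similar result with a different group on the other arm of the shared core. Also open, on these data alone, is how an unsubstituted phenyl, or a phenyl carrying an amine or a carboxylic acid, would read at this place relative to 3-fluorophenyl and 2-fluorophenyl.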